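A few compounds are considered here, and "the series" means these few. Any claim that something is new, unique, unknown or untested is made for them only; others in the source may bear on it.

Of the compounds shown here, two built on a shared core have so far been tested in a functional assay on HT-29 cells (Homo sapiens) for cytotoxicity, read by MTT assay, with a stated time of 24 h; on this read-out higher numbers stand for weaker inhibition and lower numbers for stronger inhibition. Compound 1 `Cn1c(-c2ccc(NC(=O)CSc3nc4ccccc4s3)cc2)nc(-c2ccccc2)c1-c1ccccc1` gives 18 ug/mL there. Compound 2 `CN1CCN(CC(=O)Nc2ccc(-c3nc(-c4ccccc4)c(-c4ccccc4)n3C)cc2)CC1` gives 35.5 ug/mL in this assay. Going by the values given here, the single step available, a 2.0-fold higher number from compound 1 to compound 2 (0.29 log units; within the scatter), puts 4-methylpiperazin-1-yl in place of (1,3-benzothiazol-2-yl)sulfanyl on a saturated chain carbon bound to a carbonyl carbon. On the numbers shown, compound 2 sits at the high end, yet its gap to compound 1 lies within the scatter, so the two are not told apart by this assay.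

Compound 3 `COc1ccc(CN2CCN(CC(=O)Nc3ccc(-c4nc(-c5ccccc5)c(-c5ccccc5)n4C)cc3)CC2)cc1` differs from compound 2 by 4-methoxyphenyl in place of hydrogen on a saturated chain carbon bound to an amine nitrogen in a ring; read one bond further out, methyl becomes 4-methoxybenzyl. Among the compounds with values here, no measured step touches this place: the step between compound 1 and compound 2 concerns the saturated chain carbon bound to the carbonyl carbon, and that step itself stayed within the scatter. With nothing more to lean on, a step of roughly a 1.3-fold lower number from compound 2 to compound 3 (0.10 log units; within the scatter) is expected for compound 3, that is, no shift beyond the scatter in this assay. Compound 3 is therefore estimated at 28 ug/mL in this assay, with a likely range from 9 ug/mL to 85 ug/mL.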

Compound 3, half-maximal inhibitory concentration: 77.3 ug/mL
Estimate against measurement, compound 3: 2.8-fold (0.44 log units) below, and the stated range covers the measured number.
By their numbers in this assay, from the lowest: compounds 1 and 2 (each within the scatter of the next); then compound 3.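

In this assay, going by these compounds alone, the change on the saturated chain carbon bound to an amine nitrogen in a ring gives a 2.2-fold higher number from compound 2 to compound 3 (0.34 log units; beyond the scatter), a modest shift but the only step in this short series to pass beyond the scatter. This place on the shared core therefore registers in the read-out: where methyl becomes 4-methoxybenzyl, inhibition is weaker, whereas the change on the saturated chain carbon bound to a carbonyl carbon left the two compounds unresolved, with a 2.0-fold higher number from compound 1 to compound 2 (0.29 log units; within the scatter) as its step. Nothing at hand gives a reason for this shift.

What the compounds shown leave open is which part of the entering group carries the change, the aromatic ring or the methoxy group, and a plain benzyl or a 4-hydroxybenzyl in the same place would separate these two parts. They also leave open how a hydrogen, an ethyl or a longer chain such as 2-phenylethyl would read there, and so whether the number rises steadily with the group or only with this one.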